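Substituent change on the aromatic nitrogen of compound 3

The source may hold more compounds than are shown below. What is called first, only, known or untested is meant among the compounds shown, and "the series" means these compounds.

Values in a functional assay on HT-29 cells (Homo sapiens) for inhibition, read by luminescence and CellTiter-Glo, with a stated time of 24 h; on this read-out higher numbers stand for an effect only at larger amounts of compound and lower numbers for an effect already at smaller amounts:
Compound 1 `CC(C)CCn1nc(C(=O)N[C@H]2COc3ccccc3N(C)C2=S)nc1Cc1ccccc1`: 3640 nM
Compound 2 `COCCn1nc(C(=O)N[C@H]2COc3ccccc3N(C)C2=S)nc1Cc1ccccc1`: 566 nM
Compound 3 `CN1C(=S)[C@@H](NC(=O)c2nc(Cc3ccccc3)n(CC3CCOC3)n2)COc2ccccc21`: 4420 nM

Compound 1 shares the upper end of these numbers with compound 3 at 4420 nM and the two are not separated, with a 1.2-fold higher number from compound 1 to compound 3 (0.08 log units; within the scatter) between them. Compound 2 stands clearly apart, with a 7.8-fold higher number from compound 2 to compound 3 (0.89 log units; beyond the scatter) on that side.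

Compound 4 `CN1C(=S)[C@@H](NC(=O)c2nc(Cc3ccccc3)n(C3CCNCC3)n2)COc2ccccc21` carries piperidin-4-yl in place of (oxolan-3-yl)methyl on an aromatic nitrogen, and the difference is piperidin-4-yl in place of (oxolan-3-yl)methyl on an aromatic nitrogen in full.

All three measured steps alter the group on this same nitrogen. They run from a 1.2-fold higher number from compound 1 to compound 3 (0.08 log units; within the scatter) without separation to the modest 6.4-fold lower number from compound 1 to compound 2 (0.81 log units; beyond the scatter) and the equally modest a 7.8-fold higher number from compound 2 to compound 3 (0.89 log units; beyond the scatter) on the other side. For the measured compounds named here, no measured compound carries piperidin-4-yl, so the direction is poorly fixed. A modest step is expected in this assay, leaning towards a lower number, as compound 2 at 566 nM shows that lower numbers occur with a change at this nitrogen. The expected change is a 2.2-fold lower number from compound 3 to compound 4 (0.34 log units; beyond the scatter) with wide uncertainty in either direction. Compound 4 is estimated at 2000 nM with an expected range from 400 nM to 10000 nM in this series.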

Compound 4, half-maximal effective concentration: 1000 nM
Beside the measured number, compound 4's estimate is 2.0-fold (0.30 log units) above it; the measured number falls inside the stated range.
By their numbers in this assay, from the lowest: compounds 2 and 4 (each within the scatter of the next); then compounds 1 and 3 (each within the scatter of the next).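

In this assay, piperidin-4-yl on the aromatic nitrogen gives a 4.4-fold lower number from compound 3 to compound 4 (0.65 log units; beyond the scatter) and a 3.6-fold lower number from compound 1 to compound 4 (0.56 log units; beyond the scatter), so a lower number at this position is no longer tied to 2-methoxyethyl alone. The two groups are not separated, with a 1.8-fold higher number from compound 2 to compound 4 (0.25 log units; within the scatter), which places two differently built substituents together at the lower end, while isopentyl and (oxolan-3-yl)methyl stay at the upper end. The series now shows that a ring can sit on this nitrogen without the higher number seen with compound 3, though no measurement available here accounts for the difference.

The step from compound 3 to compound 4 changes the ring size, the ring hetero atom and the presence of the chain carbon on the aromatic nitrogen all at once, so the compounds shown leave open which of these matters. Oxan-4-yl, which keeps the six-membered ring but has an oxygen in place of the ring nitrogen, and piperidin-4-ylmethyl, which restores the chain carbon, would each separate one of these changes from the others.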